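The source may hold more compounds than are shown below. What is called first, only, known or untested is meant among the compounds shown, and "the series" means these compounds.

Compound 2, `Cc1cn2c(C)c([C@H](OC(C)(C)C)C(=O)O)c(N3CCC(C)(C)CC3)c(-c3ccc(OCCc4ccc(F)cc4)cc3)c2n1`, is a close relative of compound 1, `Cc1c([C@H](OC(C)(C)C)C(=O)O)c(N2CCC(C)(C)CC2)c(-c2ccc(OCCc3ccc(F)cc3)cc2)c2nccn12`. In an ADME assay on microsomes from liver (Homo sapiens) for metabolic stability (a lower number here means that the compound disappears faster, a higher number that the compound lasts longer), compound 2 reaches > 2 h, which is a limit of the assay rather than a number. Compound 1 likewise reaches > 2 h, also a limit. The step that the two limits leave unreadable from compound 1 to compound 2 therefore cannot be sized. Compound 3, `CCc1cn2c(C)c([C@H](OC(C)(C)C)C(=O)O)c(N3CCC(C)(C)CC3)c(-c3ccc(OCCc4ccc(F)cc4)cc3)c2n1`, differs from compound 2 by methyl in place of hydrogen on a saturated chain carbon bound to an aromatic carbon. Because both measured values sit at the limit of > 2 h in this assay, at which 2 of the 2 values shown sit, no readable step in this assay bears on this change, and the expected step that the limit leaves unreadable from compound 2 to compound 3 is no larger than the usual scatter. Compound 3 is thus estimated at 2.5 h, with a likely range from 1.2 h to 6 h.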

Compound 3, half-life: > 2 h
Compound 3: no number, only a limit; the forecaster's own chance of this, stated with the estimate: 70%; the middle value lies beyond the limit too.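

No step can be read among compound 1, compound 2 and compound 3 in this assay, since each gives only a limit and not a number: the limit of > 2 h in this assay, at which 3 of the 3 values shown sit.

As far as these compounds go, what stays open is how long each compound actually lasts, and whether methyl or ethyl in place of hydrogen changes that at all.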